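Benzyl substituent changes at the purine amine of a nucleoside

This account rests on a few compounds, and the source may have more. Where it says the series, first, only, none or still open, it means among the compounds named here.

Compound 1, `OC[C@H]1O[C@@H](n2cnc3c(NCc4ccc(F)cc4)ncnc32)[C@H](O)[C@@H]1O`, gives 21000 nM in a functional assay on MCF cells (Homo sapiens) for antiproliferative activity, with a stated time of 72 h; on this read-out lower numbers stand for stronger inhibition and higher numbers for weaker inhibition.
Compound 2, `OC[C@H]1O[C@@H](n2cnc3c(NCc4ccccc4Cl)ncnc32)[C@H](O)[C@@H]1O`, reaches only the limit of this assay at > 166000 nM.

Compound 2 therefore stands at the limit of > 166000 nM in this assay, at which 1 of the 2 values shown sits; its value is a limit and not a number. Within the data shown here, the single measured step is an at least 7.9-fold higher number from compound 1 to compound 2 (0.89 log units; beyond the scatter). Compound 3, `Cc1cccc(CNc2ncnc3c2ncn3[C@@H]2O[C@H](CO)[C@@H](O)[C@H]2O)c1`, is not yet measured in this assay. It differs from compound 2 by 3-methylphenyl in place of 2-chlorophenyl on a saturated chain carbon bound to a nitrogen on an aromatic ring.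

Among the measured compounds shown here, that step from compound 1 to compound 2 is the only evidence bearing on the new change, and it runs from a measured number to a limit, so it gives an upper anchor but no direct read on a 3-methylphenyl group. The change to compound 3 removes the 2-chlorophenyl group that accompanied the move to the limit, so a return to a measurable number is expected, though not necessarily as far as compound 1. Compound 3 is expected to give 60000 nM, between 15000 nM and 200000 nM. This estimate means a step of an at least 2.7-fold lower number from compound 2 to compound 3 (0.44 log units; beyond the scatter), which is expected but uncertain, as compound 2 gives only a limit.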

Compound 3, half-maximal inhibitory concentration: > 166000 nM
Compound 3 was reported as a limit; the forecaster's own chance of this, stated with the estimate: 40%; at least 2.7-fold (0.44 log units) between middle value and limit.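

With 3-methylphenyl in place of 2-chlorophenyl, the result in this assay is still a limit and not a number, so removing the 2-chlorophenyl group is not enough on its own to bring back a measurable value. Compared with the only compound here that gives a number, the change appears as an at least 7.9-fold higher number from compound 1 to compound 3 (0.89 log units; beyond the scatter), and two different replacements of 4-fluorophenyl at this position have now led to the same limit. The step between compound 2 and compound 3 cannot be read, and the two can be placed together only by the limit they share: the limit of > 166000 nM in this assay, at which 2 of the 3 values shown sit.

Among the three compounds, 4-fluorophenyl is the only group that gives a number, but these compounds cannot show whether that depends on the fluorine, on where the substituent sits on the ring, or on both. From the compounds shown here alone, a plain phenyl, a 4-chlorophenyl or a 4-methylphenyl group in the same place would separate these readings, and how compound 2 and compound 3 rank against each other stays open.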